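A few compounds are considered here, and "the series" means these few. Any claim that something is new, unique, unknown or untested is made for them only; others in the source may bear on it.

Three compounds have been run in an assay on HEK293 cells for agonist activity at transient receptor potential cation channel subfamily M member 8 (Homo sapiens), read by fluorescence and calcium flux, with a stated time of 15 min; a lower number here means that less compound is needed, a higher number that more compound is needed for the effect:

compound 1 `CCN(Cc1cccs1)C(=O)COc1ccc(F)cc1` gives 422 nM
compound 2 `Cc1ccc(OCC(=O)N(Cc2cccs2)CC(C)C)cc1` gives 900 nM
compound 3 `CCN1C(=O)C(Oc2ccc(C)cc2)C1c1cccs1` gives "active" (no number reported)

In this assay compound 2 stands highest of the two numbers; the nearest is compound 1, whose number is lower by a margin beyond the usual scatter. Compound 3 carries a different core and gives no number to compare. For the measured compounds named here, no pair of measured compounds differs in a single place, so no step is known.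

Compound 4 `Cc1ccc(OCC(=O)N(C)Cc2cccs2)cc1` is the next entry. It differs from compound 2 as follows: hydrogen in place of isopropyl on a saturated chain carbon bound to an amide-type nitrogen. The only indication on the chain at the amide-type nitrogen is that compound 1, with a shorter chain there but also a different aryl substituent, gives 422 nM. A modest move toward a lower number is expected, though a change within the scatter would not be surprising. Compound 4 is estimated at 600 nM (range 250 nM to 1500 nM), which would mean an expected step of a 1.5-fold lower number from compound 2 to compound 4 (0.18 log units; within the scatter).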

Compound 4, half-maximal effective concentration: 400 nM
Compound 4: middle estimate off by 1.5-fold (0.18 log units), on the high side, and the stated range covers the measured number.
By their numbers in this assay, from the lowest: compounds 4 and 1 (each within the scatter of the next); then compound 2.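

In this assay, for the compounds shown here, hydrogen in place of isopropyl on a saturated chain carbon bound to an amide-type nitrogen, which reads as isobutyl to methyl, gives a 2.3-fold lower number from compound 2 to compound 4 (0.35 log units; beyond the scatter) and is the only single-place step available. It shows that the chain at this nitrogen affects the number, and that the shorter methyl chain retains agonist activity with a lower number than the isobutyl chain. No data are available to explain this step.

From the compounds shown here alone, whether a longer chain, a cyclopropylmethyl group or a hydroxyethyl chain at this nitrogen would continue or reverse the change remains open. Compound 1 differs from compound 4 in more than one place, so its ethyl chain does not establish a trend with chain length.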